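Chloro in place of methoxy: an expectation for compound 4

The source may hold more compounds than are shown below. What is called first, only, known or untested is meant among the compounds shown, and "the series" means these compounds.

In a functional assay on SH-SY5Y cells (Homo sapiens) for cytotoxicity, read by MTT assay, with a stated time of 48 h (on this read-out higher numbers stand for weaker inhibition and lower numbers for stronger inhibition), compound 1 (`COc1ccc(/C=C/C(=O)/C=C/c2nc3ccccc3n2C)cc1O`) gives 4800 nM, compound 2 (`COc1ccc(/C=C/C(=O)/C=C/c2nc3cc(C)ccc3n2C)cc1O`) gives 4800 nM and compound 3 (`COc1ccc2c(c1)nc(/C=C/C(=O)/C=C/c1ccc(OC)c(O)c1)n2C`) gives 4800 nM. Compound 3 therefore stands level with compounds 1 and 2.

The next structure is compound 4 (`COc1ccc(/C=C/C(=O)/C=C/c2nc3cc(Cl)ccc3n2C)cc1O`), with chloro in place of methoxy on an aromatic carbon.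

Among the compounds with values here, three measured steps bear on this change. Methyl in place of hydrogen gives no change at the digits printed from compound 1 to compound 2 (within the scatter), methoxy in place of hydrogen gives no change at the digits printed from compound 1 to compound 3 (within the scatter), and methoxy in place of methyl gives no change at the digits printed from compound 2 to compound 3 (within the scatter). All three lie within the scatter. Within the data shown here, no chloro compound has been measured in this set, so the expectation rests on these three compounds alone. No step beyond the scatter is expected in this assay, and no direction is favoured. The expected step is a 1.1-fold lower number from compound 3 to compound 4 (0.03 log units; within the scatter). The estimate for compound 4 is 4500 nM, with an estimated range of 2200 nM to 9000 nM.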

Compound 4, half-maximal inhibitory concentration: 4800 nM
For compound 4 the middle estimate is 1.1-fold (0.03 log units) below the measured one; the measured number falls inside the stated range.
By their numbers in this assay, from the lowest: compounds 1, 2, 3 and 4 (each within the scatter of the next).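

In (this assay), chloro joins hydrogen, methyl and methoxy at this aromatic carbon without a step beyond the scatter: (no change at the digits printed from compound 3 to compound 4 (within the scatter)), (no change at the digits printed from compound 2 to compound 4 (within the scatter)) and (no change at the digits printed from compound 1 to compound 4 (within the scatter)). The series now shows that a halogen is tolerated here as well, and that exchanging methoxy, with its hydrogen-bond acceptor and two heavy atoms, for chloro, with no acceptor and one heavy atom, does not separate the two compounds on this read-out. No measurement at hand accounts for this flat result.

Going by these compounds, whether an amine, a carboxylic acid or a longer chain at this position would shift the number remains open. The compounds shown also leave open what replacing the hydroxy or methoxy group elsewhere on the shared core would do.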